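This account rests on a few compounds, and the source may have more. Where it says the series, first, only, none or still open, it means among the compounds named here.

Measured so far: compound 1 `CC[C@@H](Nc1c(C#N)c(-c2ccc(-c3ccccc3NC)cc2)nc2cnccc12)C(N)=O` gives 2.5, compound 2 `CC[C@@H](Nc1c(C#N)c(-c2ccc(-c3ccc(F)cc3)cc2)nc2cnccc12)C(N)=O` gives 2.7, and compound 3 `CC[C@@H](Nc1c(C#N)c(-c2ccc(-c3ccccc3C(C)C)cc2)nc2cnccc12)C(N)=O` gives 3.5 in a physicochemical assay for lipophilicity, read by HPLC, at pH 7.5; on this read-out higher numbers stand for higher lipophilicity and lower numbers for lower lipophilicity.

Compound 3 stands highest of the three on this assay, beyond the scatter from both others. Compound 4 `CC[C@@H](Nc1c(C#N)c(-c2ccc(-c3ccccc3N(C)C)cc2)nc2cnccc12)C(N)=O` differs from it as follows: dimethylamino in place of isopropyl on an aromatic carbon. The step that bears most directly on this change is a number 1.00 log units higher from compound 1 to compound 3 (beyond the scatter), since the methylamino of compound 1 and the dimethylamino of compound 4 differ by a single carbon; a number 0.80 log units higher from compound 2 to compound 3 (beyond the scatter) also shows the isopropyl end of the series sitting high. A step downward beyond the scatter, but short of a full reversal of the step from compound 1, is therefore expected: a number 0.60 log units lower from compound 3 to compound 4 (beyond the scatter). Compound 4 is estimated at 2.9, within 2.5 to 3.3.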

Compound 4, distribution coefficient: 3.2
Beside the measured number, compound 4's estimate is 0.30 log units below it; the measured number falls inside the stated range.
By their numbers in this assay, from the lowest: compounds 1 and 2 (each within the scatter of the next); then compounds 4 and 3 (each within the scatter of the next).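

In this assay the exchange of isopropyl for dimethylamino on this aromatic carbon reads as a number 0.30 log units lower from compound 3 to compound 4 (within the scatter) and so leaves the two groups unresolved, even though dimethylamino brings a nitrogen and a hydrogen-bond acceptor. The added methyl on the nitrogen gives a number 0.70 log units higher from compound 1 to compound 4 (beyond the scatter) and stands out from the scatter, while the exchange of the 4-fluorophenyl gives a number 0.50 log units higher from compound 2 to compound 4 (beyond the scatter) as a further step of modest size. Nothing measured here explains these steps.

On these data alone, whether an unsubstituted amine or a methoxy group at this place would read with dimethylamino or with methylamino stays open. So does whether a longer chain on the nitrogen would extend the step seen with methyl.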